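The source may report more compounds than this note shows. Statements on the series, on what has been measured and on what is new or still open speak of the compounds shown alone.

Measured compounds:
- compound 1, `COc1ccc([C@@H]2CC(=O)c3c(O)cc(OCc4cn(Cc5ccccc5C#N)nn4)cc3O2)cc1O`, 14600 nM
- compound 2, `COc1ccc([C@@H]2C/C(=N\O)c3c(O)cc(OCc4cn(-c5ccccc5)nn4)cc3O2)cc1O`, 6130 nM

Of the compounds shown here, two have been measured in a functional assay on RAW264.7 cells (Mus musculus) for inhibition, read by Griess assay, with stated times of 2 h and 24 h; on this read-out lower numbers stand for stronger inhibition and higher numbers for weaker inhibition. Compound 1 gives 14600 nM, the highest of the two numbers; its nearest neighbour, compound 2, gives 6130 nM, a lower number that lies beyond the usual scatter. The two share the same core but differ in more than one place, so the gap between them cannot be assigned to a single change.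

Compound 3, `COc1ccc([C@@H]2CC(=O)c3c(O)cc(OCc4cn(Cc5ccccc5C)nn4)cc3O2)cc1O`, has not yet been measured in this assay. Compared with compound 1 it carries the following difference: methyl in place of cyano on an aromatic carbon. Going by the values given here, no single-change step between measured compounds exists to guide this change, so its effect remains open. The step of a 1.2-fold lower number from compound 1 to compound 3 (0.09 log units; within the scatter) is expected to stay within the usual scatter, with no clear direction. Compound 3 is therefore estimated at 12000 nM, within a range from 4500 nM to 32000 nM.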

Compound 3, half-maximal inhibitory concentration: 13100 nM
For compound 3 the middle estimate is 1.1-fold (0.04 log units) below the measured one; the measured number falls inside the stated range.
By their numbers in this assay, from the lowest: compound 2; then compounds 3 and 1 (each within the scatter of the next).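

In this assay, going by these compounds alone, replacing 2-cyanobenzyl with 2-methylbenzyl gives a 1.1-fold lower number from compound 1 to compound 3 (0.05 log units; within the scatter) and so stays within the scatter, the first single-change reading at this place on the shared core. Cyano brings a triple bond and a hydrogen-bond acceptor and methyl brings neither, yet on this read-out the two compounds cannot be told apart. No independent measurement is available to explain this result.

It remains open whether this place would respond to a different kind of group, such as an amine or a carboxylic acid, since only cyano and methyl are shown there. Compound 2 differs from compound 1 and compound 3 in more than one place, so nothing shown assigns its lower number to any single change.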